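Replacing 1-(trifluoromethyl)cyclopropyl with oxan-4-yl in compound 2

This account rests on a few compounds, and the source may have more. Where it says the series, first, only, none or still open, it means among the compounds named here.

Measured in an ADME assay on microsomes from liver (Rattus norvegicus) for metabolic stability, read by LC-MS, tested at 1 uM; on this read-out lower numbers stand for a shorter-lived compound and higher numbers for a longer-lived compound:
Compound 1 `Nc1ncnc2c1c(Oc1cccc(Cl)c1)nn2CC1CCNCC1`: > 1 h (a limit)
Compound 2 `Nc1ncnc2c1c(Oc1cccc(Cl)c1)nn2CC1(C(F)(F)F)CC1`: 0.183 h
Compound 3 `CC(C)(C)n1nc(Sc2cccc(Cl)c2)c2c(N)ncnc21`: 0.04 h

Of the two exact numbers, compound 2 holds the higher at 0.183 h, while compound 3 gives 0.04 h. The entry for compound 1 is a limit, not a number.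

Compound 4 `Nc1ncnc2c1c(Oc1cccc(Cl)c1)nn2CC1CCOCC1` differs from compound 2 in one place: oxan-4-yl in place of 1-(trifluoromethyl)cyclopropyl on a saturated chain carbon bound to an aromatic nitrogen. Here, oxan-4-yl stands in place of 1-(trifluoromethyl)cyclopropyl on a saturated chain carbon bound to an aromatic nitrogen.

Among the compounds with values here, one measured step bears on this change: an at least 5.4-fold lower number from compound 1 to compound 2 (0.73 log units; beyond the scatter), beyond the scatter, which introduced the group now leaving, in place of piperidin-4-yl. A partial reversal is therefore expected, upward and beyond the scatter, as a 2.7-fold higher number from compound 2 to compound 4 (0.44 log units; beyond the scatter). For compound 4 the estimated value is 0.5 h, within an expected range of 0.2 h to 1.3 h.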

Compound 4, half-life: 0.233 h
The estimate for compound 4 lay 2.1-fold (0.33 log units) above the measured number, within the range that was stated.
By their numbers in this assay, from the lowest: compound 3; then compounds 2 and 4 (each within the scatter of the next). At a limit, above all of these: compound 1.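

In this assay, two different groups on a saturated chain carbon bound to an aromatic nitrogen read alike: a 1.3-fold higher number from compound 2 to compound 4 (0.10 log units; within the scatter). Oxan-4-yl therefore does not separate from 1-(trifluoromethyl)cyclopropyl here, and the difference from piperidin-4-yl remains, as an at least 4.2-fold lower number from compound 1 to compound 4 (0.63 log units; beyond the scatter). The entry for compound 1 is a limit, not a number: the limit of > 1 h in this assay, at which 1 of the 4 values shown sits.

The compounds shown leave open whether the ring nitrogen of piperidin-4-yl is what sets compound 1 apart. An open-chain amine or a carboxylic acid on the same chain carbon would bear on that question.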